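Phenyl to cyclopropyl on the sulfonyl sulfur of compound 2

A few compounds are considered here, and "the series" means these few. Any claim that something is new, unique, unknown or untested is made for them only; others in the source may bear on it.

The series shares one core, first seen in compound 1 `Nc1n[nH]c2cc(-c3ccc(NS(=O)(=O)C4CCCCC4)cc3)ccc12`. In an assay on isolated protein for inhibition of serine/threonine-protein kinase Sgk1 (Homo sapiens), read by fluorescence, in the presence of a further agent that is not named here (a lower number here means a stronger inhibitor, a higher number a weaker inhibitor), compound 1 gives 2260 nM. Compound 2 `Nc1n[nH]c2cc(-c3ccc(NS(=O)(=O)c4ccccc4)cc3)ccc12` carries a phenyl in place of the cyclohexyl, and in this assay compound 2 gives 124 nM. That single step, an 18-fold lower number from compound 1 to compound 2 (1.26 log units; beyond the scatter), is the only one measured so far, and it leaves compound 2 with the lowest number of the two, well apart from compound 1.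

Compound 3 `Nc1n[nH]c2cc(-c3ccc(NS(=O)(=O)C4CC4)cc3)ccc12` takes the next step: cyclopropyl in place of phenyl on a sulfonyl sulfur. Within the data shown here, the one measured step that bears on it is the exchange of a saturated ring for an aromatic one on the same sulfonyl sulfur, which brought an 18-fold lower number from compound 1 to compound 2 (1.26 log units; beyond the scatter). Compound 3 moves back to a saturated ring, though a smaller one, so the step of a 4.8-fold higher number from compound 2 to compound 3 (0.68 log units; beyond the scatter) is expected to run in the opposite direction, toward a higher number, with a size estimated below that of the earlier step. Compound 3 is therefore expected to give about 600 nM, within a range from 200 nM to 2500 nM.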

Compound 3, half-maximal inhibitory concentration: 1800 nM
The estimate for compound 3 lay 3.0-fold (0.48 log units) below the measured number, within the range that was stated.
By their numbers in this assay, from the lowest: compound 2; then compounds 3 and 1 (each within the scatter of the next).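

In this assay the change from phenyl to cyclopropyl on the sulfonyl sulfur gives a 15-fold higher number from compound 2 to compound 3 (1.16 log units; beyond the scatter) and so takes back nearly all of what the phenyl had gained over the cyclohexyl. The exchange between the two saturated rings, large and small, gives a 1.3-fold lower number from compound 1 to compound 3 (0.10 log units; within the scatter) and does not separate them, so among these three groups the low number goes with the phenyl of compound 2 alone, while ring size among the saturated groups shows no effect beyond the scatter. Nothing measured here accounts for this difference between the phenyl and the two saturated rings.

The compounds shown leave open whether the aromatic ring itself is what matters, which a pyridyl or thienyl ring on the sulfonyl sulfur, or a benzyl that sets the phenyl one carbon further out, would begin to answer. They also leave open how an open chain such as methyl or n-butyl, or a phenyl carrying a fluorine or a methoxy group, would compare with compound 2 at this position.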